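The source may hold more compounds than are shown below. What is called first, only, known or untested is meant among the compounds shown, and "the series" means these compounds.

Compound 1 `Cn1cncc1C(OCc1ccc(C#N)cc1C#Cc1cccc(O)c1)c1ccc(C#N)cc1`: > 0.1 nM
Compound 2 `Cn1cncc1C(OCc1ccc(C#N)cc1/C=C/c1ccccn1)c1ccc(C#N)cc1`: 23.1 nM
Compound 3 `Cn1cncc1C(OCc1ccc(C#N)cc1-c1ccc(-c2ccccc2)cc1)c1ccc(C#N)cc1`: < 0.1 nM

In a functional assay on NIH3T3 cells (Mus musculus) (on this read-out lower numbers stand for an effect already at smaller amounts and higher numbers for an effect only at larger amounts of compound), compound 1 gives > 0.1 nM, which is a limit of the assay and not a number. In this assay compound 2 gives 23.1 nM. Compound 3 gives < 0.1 nM, again a limit of the assay rather than a measured number. Among the measured compounds shown here, compound 3 therefore stands at the low edge of what the assay can report, and the one step that can be read in full is an at least 230-fold lower number from compound 2 to compound 3 (2.36 log units; beyond the scatter). The other step to compound 3, a number no higher from compound 1 to compound 3 (the limit leaves the size open), leaves its size open.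

Compound 4 `Cn1cncc1C(OCc1ccc(C#N)cc1C#Cc1ccc([N+](=O)[O-])cc1)c1ccc(C#N)cc1` differs from compound 3 in one place: 2-(4-nitrophenyl)ethynyl in place of 4-phenylphenyl on an aromatic carbon. The change undoes the 4-phenylphenyl group and brings back a ring joined through a triple bond, as in compound 1. The step of an at least 230-fold lower number from compound 2 to compound 3 (2.36 log units; beyond the scatter) therefore bears on it in reverse, and a higher number for compound 4 than for compound 3 is expected, of a size that the limits on compound 1 and compound 3 leave uncertain. The estimated step is an at least 30-fold higher number from compound 3 to compound 4 (1.47 log units; beyond the scatter). For compound 4 the expected value in this assay is 3 nM, with a range from 0.3 nM to 30 nM.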

Compound 4, half-maximal effective concentration: 36 nM
Compound 4: the middle estimate sits 12-fold (1.08 log units) below what was measured, and the stated range ends below it.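

The group on this aromatic carbon, ortho to a large group and meta to a cyano group, carries a great deal of weight: putting 2-(4-nitrophenyl)ethynyl in place of 4-phenylphenyl gives an at least 360-fold higher number from compound 3 to compound 4 (2.55 log units; beyond the scatter). As far as these compounds go, the true size of that step stays open, since compound 3 sits at a limit of the assay and not at a measured number: the limit of < 0.1 nM in this assay, at which 1 of the 4 values shown sits. The 2-(pyridin-2-yl)ethenyl and 2-(4-nitrophenyl)ethynyl groups cannot be told apart here, with a 1.6-fold higher number from compound 2 to compound 4 (0.19 log units; within the scatter), so among the readable values a ring joined through a double bond and one joined through a triple bond sit together, and only 4-phenylphenyl stands clear of both.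

From the compounds shown here alone, the step that links compound 1 with compound 4 cannot be read, so it stays open whether 3-hydroxyphenyl and 4-nitrophenyl differ on the triple bond. Also open, going by these compounds, is whether the result for compound 3 rests on the second ring of 4-phenylphenyl or on its direct attachment to the core, and how a plain phenyl ring, or a ring carrying an amine or a carboxylic acid, would fare at this place.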